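Amide side chain change from compound 3 to compound 4

A few compounds are considered here, and "the series" means these few. Any claim that something is new, unique, unknown or untested is made for them only; others in the source may bear on it.

In a functional assay on PC-3 cells (Homo sapiens) for antiproliferative activity, read by MTT assay, with a stated time of 24 h (on this read-out lower numbers stand for stronger inhibition and higher numbers for weaker inhibition), compound 3 (`CCn1c(C(=O)NC(C)(C)CO)ccc1C(CC)(CC)c1ccc(OCS(=O)(=O)c2ccccc2)c(C)c1`) gives 9850 nM. This lies within the scatter of compound 2 (`CCn1c(C(=O)N[C@@H](C)CO)ccc1C(CC)(CC)c1ccc(OCS(=O)(=O)c2ccccc2)c(C)c1`), at 9520 nM, and of compound 1 (`CCN(CC)CCNC(=O)c1ccc(C(CC)(CC)c2ccc(OCS(=O)(=O)c3ccccc3)c(C)c2)n1CC`), at 7130 nM.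

Compound 4 (`CCn1c(C(=O)N[C@@H](CO)CCCO)ccc1C(CC)(CC)c1ccc(OCS(=O)(=O)c2ccccc2)c(C)c1`) keeps the core of compound 3 and alters only the group on the amide-type nitrogen: a group of 7 heavy atoms (5 carbon, 2 oxygen; no ring) in place of a group of 5 heavy atoms (4 carbon, 1 oxygen; no ring), on an amide-type nitrogen. The entering group also has 1 defined stereocentre.

Going by the values given here, three measured steps bear on this change, all at the same nitrogen: a 1.3-fold higher number from compound 1 to compound 2 (0.13 log units; within the scatter), a 1.4-fold higher number from compound 1 to compound 3 (0.14 log units; within the scatter) and a 1.0-fold higher number from compound 2 to compound 3 (0.01 log units; within the scatter). None of the three goes beyond the scatter, so these three compounds give no sign that this assay responds to changes at this nitrogen. Among the compounds with values here, that evidence is thin, as it rests on only three compounds, and none of them carries the entering group.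

The expected change is no more than the scatter, with no direction favoured: a 1.1-fold lower number from compound 3 to compound 4 (0.04 log units; within the scatter). For compound 4 the estimated value is 9000 nM, with an expected range of 5000 nM to 16000 nM.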

Compound 4, half-maximal inhibitory concentration: 13400 nM
Estimate against measurement, compound 4: 1.5-fold (0.17 log units) below; low and high end bracket the measured number.
By their numbers in this assay, from the lowest: compounds 1, 2, 3 and 4 (each within the scatter of the next).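

A group of 7 heavy atoms with 2 hydrogen-bond donors, 2 hydrogen-bond acceptors and 1 defined stereocentre can now be placed on the amide-type nitrogen with no step beyond the scatter in this assay: the readings are a 1.4-fold higher number from compound 3 to compound 4 (0.13 log units; within the scatter) and a 1.4-fold higher number from compound 2 to compound 4 (0.15 log units; within the scatter). The widest gap in the set, a 1.9-fold higher number from compound 1 to compound 4 (0.27 log units; within the scatter), compares two groups of 7 heavy atoms, one with 2 oxygens and one with 1 nitrogen, and it too stays within the scatter, so the insensitivity seen earlier extends to all four compounds. Nothing on hand offers an explanation for these numbers.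

On these data alone, whether a carboxylic acid, a phenyl ring or a much longer alkyl chain on this nitrogen would move the number beyond the scatter remains open. So does the effect of the opposite configuration at the stereocentre of the entering group.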